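The source may report more compounds than this note shows. Statements on the series, on what has been measured and on what is new or still open speak of the compounds shown alone.

Compound 1 `COc1ccc(NC(=O)C(=O)c2cn(CC(C)(C)OC)c3ccccc23)cn1` is the starting point of this account. In a functional assay on FaDu cells (Homo sapiens) for cytotoxicity, read by MTT assay, with a stated time of 72 h (on this read-out lower numbers stand for higher toxicity in this test and higher numbers for lower toxicity in this test), compound 1 gives > 10000 nM, and this is a limit of the assay rather than a measured number. Compound 1 therefore stands at the limit of > 10000 nM in this assay, at which 1 of the 2 values shown sits. For the measured compounds named here, compound 2 `COc1nsc(NC(=O)C(=O)c2cn(C(C)C)c3ccccc23)n1` differs from compound 1 in more than one place, so no single step joins the two; in this assay compound 2 gives 10400 nM, the only number among the two values shown. Compound 3 `CCCCn1cc(C(=O)C(=O)Nc2ccc(OC)nc2)c2ccccc21` has not yet been tested in this assay. The change from compound 1 is propyl in place of 1-methoxy-1-methylethyl on a saturated chain carbon bound to an aromatic nitrogen; read one bond further out, it is 2-methoxy-2-methylpropyl to butyl. Going by the values given here, with compound 1 known only as a limit, no measured step is available to anchor the size of the change, and the step of an at least 2.0-fold lower number from compound 1 to compound 3 (0.30 log units; that floor lies within the scatter) is expected to run toward higher toxicity, though a change no larger than the scatter would not surprise. Compound 3 is expected to give about 5000 nM, between 500 nM and 30000 nM.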

Compound 3, concentration lethal to 50% of the cells: 18 nM
Estimate against measurement, compound 3: 280-fold (2.44 log units) above, outside the stated range (below it).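

In this assay, replacing 2-methoxy-2-methylpropyl with butyl on the saturated chain carbon bound to an aromatic nitrogen gives an at least 550-fold lower number from compound 1 to compound 3 (2.74 log units; beyond the scatter), toward higher toxicity in this test. For the compounds shown here, this is the first single-place comparison in the account, and it shows that the read-out depends strongly on the group at this place. The size of the step is a minimum, as the value for compound 1 is a limit of the assay and not a number: the limit of > 10000 nM in this assay, at which 1 of the 3 values shown sits.

Going by these compounds alone, the single step changes the methoxy oxygen, the branching and the heavy-atom count of the group together, so it cannot say which of these matters. On these data alone, how a longer chain such as hexyl, or a butyl chain carrying an amine, would read at this place also stays open.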